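Swapping Amine Ends on Two Related Cores

The source may hold more compounds than are shown below. What is called first, only, known or untested is meant among the compounds shown, and "the series" means these compounds.

Compound 1 `CN(C)CCCCn1c(N)c(-c2nc3ccccc3o2)c2nc(C#N)c(C#N)nc21` and compound 2 `CCN(CC)CCCCn1c(N)c(-c2nc3ccccc3o2)c2nc(C#N)c(C#N)nc21` share one core. In a functional assay on K562 cells (Homo sapiens) for antiproliferative activity, read by MTT assay, with a stated time of 48 h (on this read-out lower numbers stand for stronger inhibition and higher numbers for weaker inhibition), compound 1 gives 1380 nM, and compound 2 gives 1980 nM. The difference between them is diethylamino in place of dimethylamino on a saturated chain carbon, four bonds along the chain from an aromatic nitrogen, and it produced a 1.4-fold higher number from compound 1 to compound 2 (0.16 log units; within the scatter). Compound 3 `CN(C)CCCn1c(N)c(-c2nc3cc(Cl)ccc3[nH]2)c2nc(C#N)c(C#N)nc21` carries a different core; how the two cores differ is not broken down here. In this assay compound 3 gives 10700 nM, a higher number than either compound 1 or compound 2 by more than the usual scatter. Compound 4 `CCN(CC)CCCn1c(N)c(-c2nc3cc(Cl)ccc3[nH]2)c2nc(C#N)c(C#N)nc21` has not been measured. It differs from compound 3 by diethylamino in place of dimethylamino on a saturated chain carbon, three bonds along the chain from an aromatic nitrogen, the same kind of change as before, though here the amine sits three bonds along the chain from the aromatic nitrogen rather than four. A step of similar size is expected, a 1.3-fold higher number from compound 3 to compound 4 (0.12 log units; within the scatter), because the earlier step read a 1.4-fold higher number from compound 1 to compound 2 (0.16 log units; within the scatter). Compound 4 is therefore estimated at 14000 nM, with a range from 7000 nM to 28000 nM.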

Compound 4, half-maximal inhibitory concentration: 4830 nM
Compound 4: the middle estimate sits 2.9-fold (0.46 log units) above what was measured; measured number outside the range, below it.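

In this assay, diethylamino in place of dimethylamino gave a 2.2-fold lower number from compound 3 to compound 4 (0.35 log units; beyond the scatter). Set beside the earlier step, the same change did not carry over unchanged from one core to the other: the same change on two cores in this assay, a 1.4-fold higher number (0.16 log units; within the scatter) from compound 1 to compound 2 and a 2.2-fold lower number (0.35 log units; beyond the scatter) from compound 3 to compound 4, 3.2-fold (0.50 log units) apart, beyond the scatter of two such steps. Among the compounds shown here, this warns against assuming that the effect of this swap transfers, but it does not show why the steps differ: the two pairs differ in core and also in chain, with the amine four bonds along in one and three in the other, and each core offers only one pair.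

On these data alone, it remains open whether the core or the chain matters more. As far as these compounds go, how a dipropylamino end or a longer chain would behave on either core also remains open.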